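A few compounds are considered here, and "the series" means these few. Any claim that something is new, unique, unknown or untested is made for them only; others in the source may bear on it.

Measured so far in an ADME assay on L1210/0 cells (Mus musculus) for cytotoxicity, with a stated time of 48 h (on this read-out higher numbers stand for weaker inhibition and lower numbers for stronger inhibition), for the two compounds

- compound 1 `C=C(Cl)c1cn([C@H]2C[C@H](O)[C@@H](CO)O2)c(=O)[nH]c1=O` gives 1660 nM
- compound 2 `O=C(CI)NCc1cn([C@H]2C[C@H](O)[C@@H](CO)O2)c(=O)[nH]c1=O` gives 107000 nM

Compound 2 has the higher number of the pair, so it is the weaker inhibitor. Compound 3 `N#Cc1cn([C@H]2C[C@H](O)[C@@H](CO)O2)c(=O)[nH]c1=O` differs from it as follows: cyano in place of (((iodomethyl)carbonyl)amino)methyl on an aromatic carbon. For the measured compounds named here, only one measured step touches this place, the large 64-fold higher number from compound 1 to compound 2 (1.81 log units; beyond the scatter) in the same read-out. It shows that this place can matter in this assay but gives no firm direction, since compound 3 carries neither group from that step. A moderate move to a lower number is therefore expected, and the expected change is a 2.7-fold lower number from compound 2 to compound 3 (0.43 log units; beyond the scatter) with much uncertainty. Compound 3 is estimated at 40000 nM with an expected range from 6000 nM to 250000 nM in this measurement.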

Compound 3, half-maximal inhibitory concentration: > 200000 nM
Compound 3: a limit, no number (the forecaster's own chance of this, stated with the estimate: 25%); middle value at least 5.0-fold (0.69 log units) from the limit.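

In this assay compound 3 gives a limit and not a number: the limit of > 200000 nM in this assay, at which 1 of the 3 values shown sits.
Cyano in place of the longer (((iodomethyl)carbonyl)amino)methyl gives an at least 1.8-fold higher number from compound 2 to compound 3 (0.27 log units; that floor lies within the scatter) and so brings no clear gain at this position, although the floor of that step does not firmly separate the two compounds. Cyano in place of 1-chloroethenyl gives an at least 120-fold higher number from compound 1 to compound 3 (2.08 log units; beyond the scatter) and leaves compound 1 with the lowest number of the three.

On these data alone, how far compound 3 lies past its limit stays unknown. As far as these compounds go, whether plain ethenyl, without the chlorine, or an amine at this place would stay close to compound 1 also remains open.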